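The compounds below may be only part of what the source reports. "The series", "measured", "known", "first", "only" and "open" are said of these compounds alone.

Compound 1 `COc1ccc2c(=O)c(/C=C/C(=O)NCc3cccc(F)c3)coc2c1`: in a functional assay on L02 cells (Homo sapiens) for inhibition, read by MTT assay, with a stated time of 48 h (a higher number here means a weaker inhibitor, a lower number a stronger inhibitor), compound 1 gives > 200000 nM, which is a limit of the assay and not a number.
Compound 2 `COc1ccc2c(=O)c(/C=C/C(=O)Nc3ccccc3OC)coc2c1`: in this assay compound 2 gives > 200000 nM, again only a limit.
Compound 3 `COc1ccc2c(=O)c(/C=C/C(=O)NCc3ccc(C)cc3)coc2c1`: in this assay compound 3 gives > 200000 nM, again only a limit.

Compound 3 therefore has no fixed place on a scale: its value is a limit, and so are the two other values, all three sitting at the limit of > 200000 nM in this assay, at which 3 of the 3 values shown sit. None of the steps between the measured compounds can be read for size: a step that the two limits leave unreadable from compound 1 to compound 2, a step that the two limits leave unreadable from compound 1 to compound 3 and a step that the two limits leave unreadable from compound 2 to compound 3 all run between two limits.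

Compound 4 `COc1ccc2c(=O)c(/C=C/C(=O)Nc3ccc(C)cc3)coc2c1` has not yet been measured in this assay. It differs from compound 3 in a single place: 4-methylphenyl in place of 4-methylbenzyl on an amide-type nitrogen. The steps from compound 1 to compound 2 and from compound 2 to compound 3 each swap a benzyl-type group for a phenyl-type group on the same amide nitrogen, the same kind of exchange, yet neither gives a readable size. Within the data shown here, there is thus no measured step from which a direction or a size could be expected; the only sound expectation is that compound 4 also reaches the limit of the assay.

For compound 4 the estimate in this assay is 300000 nM, with a range from 150000 nM to 2000000 nM. The step from compound 3 to compound 4 is expected to be a step that the limit leaves unreadable from compound 3 to compound 4, most likely again reported only as a limit.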

Compound 4, half-maximal inhibitory concentration: > 200000 nM
Compound 4: only a limit was reported; the forecaster's own chance of this, stated with the estimate: 85%; the middle value does not contradict the limit.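

Compound 4 gives only a limit in this assay, as do compound 1, compound 2 and compound 3, so no step among these four compounds can be read for size: the limit of > 200000 nM in this assay, at which 4 of the 4 values shown sit.

The compounds shown leave open how strongly any of them inhibits, and whether changing the group on the amide-type nitrogen alters that at all.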